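The source may hold more compounds than are shown below. What is called first, only, known or untested is meant among the compounds shown, and "the series" means these compounds.

Compound 1 `COc1ccccc1S(=O)(=O)/C=C/c1cccnc1` and compound 2 `COc1ccc(S(=O)(=O)/C=C/c2cccnc2)cc1` are built from the same atoms joined differently; the difference between the two cores is not broken down here. In an ADME assay on BV-2 cells (Mus musculus) for cytotoxicity, with a stated time of 24 h, tested at 10 uM (a higher number here means a weaker effect of the compound at the concentration tested, a lower number a stronger effect), compound 1 gives 100%, and compound 2 gives 99.5%, two numbers that lie within the scatter of one another. Compound 3 `COc1ccccc1S(=O)(=O)/C=C/c1ccncc1` arises from compound 1 by pyridin-4-yl in place of pyridin-3-yl on a double-bonded chain carbon bound to a double-bonded chain carbon. In this assay compound 3 gives 96.8%; the step of a number 3.2 percentage points lower from compound 1 to compound 3 (within the scatter) lies within the scatter, so no change in the read-out can be claimed for this exchange among the three compounds measured. Compound 4 `COc1ccc(S(=O)(=O)/C=C/c2ccncc2)cc1`, not yet measured, arises from compound 2 by pyridin-4-yl in place of pyridin-3-yl on a double-bonded chain carbon bound to a double-bonded chain carbon, the same change at the same place, made on the core of compound 2 rather than on that of compound 1. Since that exchange on compound 1 gave a number 3.2 percentage points lower from compound 1 to compound 3 (within the scatter), the corresponding step onto compound 4 is expected to be of about the same small size, estimated as a number 2.5 percentage points lower from compound 2 to compound 4 (within the scatter). On this basis compound 4 is estimated to give 97% in this assay, with an expected range from 90% to 102%.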

Compound 4, a percentage reported as activity, at one concentration (the size of the read-out at that concentration, not a potency): 71%
For compound 4 the middle estimate is 26 percentage points above the measured one; the measured number lies below the stated range.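

In this assay, the exchange of pyridin-3-yl for pyridin-4-yl does not carry over from one core to the other at the same size, as the two steps show: the same change on two cores in this assay, a number 3.2 percentage points lower (within the scatter) from compound 1 to compound 3 and a number 28.5 percentage points lower (beyond the scatter) from compound 2 to compound 4, 25.3 percentage points apart, beyond the scatter of two such steps. The exchange that left no claimable change on the core of compound 1 gives a number 28.5 percentage points lower from compound 2 to compound 4 (beyond the scatter), so the core on which it is made matters in this small series, and a step read on one of these cores is no safe guide to the other. This rests on a single pair of steps read at one concentration, so it shows that the two cores differ in their response to this exchange, but not why they differ or whether other exchanges would behave in the same way.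

All four compounds carry a pyridine ring and a methoxy group, so the compounds shown leave open whether the same dependence on the core would appear with other groups. An amine or a carboxylic acid in place of the methoxy group might respond differently, and the same question stands for a plain phenyl ring in place of the pyridine.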